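The source may report more compounds than this note shows. Statements on the series, on what has been measured and on what is new or still open speak of the compounds shown alone.

In an assay on membranes from liver for displacement of a labelled ligand from Sigma intracellular receptor 2 (Rattus norvegicus), read by scintillation counting (a lower number here means a stronger inhibitor, a higher number a weaker inhibitor), two compounds have so far been measured. Compound 1, `c1ccc(CCCCNCC[C@@H]2CCC[C@H](c3ccccc3)O2)cc1`, gives 234 nM, and compound 2, `c1ccc([C@H]2CCC[C@@H](CCN3CCCC3)O2)cc1`, gives 115 nM. Compound 1 thus holds the higher of the two numbers, and the gap between it and compound 2 is beyond the usual scatter of repeated measurements, so compound 1 is the weaker inhibitor of the pair.

Compound 3, `c1ccc(CCCCNCC[C@H]2CCC[C@@H](c3ccccc3)O2)cc1`, has not yet been measured. Against compound 1 the difference is the two compounds have the same atoms and bonds and differ only in configuration as drawn: 2 of 2 stereo elements differ (all stereocentres are inverted: mirror images); a stereocentre at a saturated ring carbon is drawn S in compound 1 and R in compound 3; a stereocentre at a saturated ring carbon is drawn R in compound 1 and S in compound 3. Going by the values given here, no pair of measured compounds shows the effect of such a change, so the data give no guide to its size or direction. Mirror images may give alike or very different numbers, and nothing measured here decides between these outcomes. The step is therefore expected to be none beyond the scatter as a middle estimate, with a broad range on either side: a 1.2-fold lower number from compound 1 to compound 3 (0.07 log units; within the scatter). Compound 3 is accordingly estimated at 200 nM, within a range from 50 nM to 1000 nM.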

Compound 3, inhibition constant: 377 nM
Beside the measured number, compound 3's estimate is 1.9-fold (0.28 log units) below it; the measured number falls inside the stated range.
By their numbers in this assay, from the lowest: compound 2; then compounds 1 and 3 (each within the scatter of the next).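

Until this pair, nothing measured in this assay had shown what inverting the stereocentres does, and compounds 1 and 3 now give the first reading of that change (a 1.6-fold higher number from compound 1 to compound 3 (0.21 log units; within the scatter)). With both stereocentres at the saturated ring carbons inverted, the two mirror images cannot be told apart in this assay, so for this pair the configuration as drawn does not separate the numbers beyond the usual scatter of repeated measurements. The comparison isolates that single change, and any reading of the step can point to only one structural difference: the fact that compounds 1 and 3 differ only in the configuration as drawn.

The compounds shown leave open whether inverting only one of the two stereocentres would give a number in line with these two, since here both change together, and whether the same lack of separation would hold for mirror images carrying a different amine, such as the pyrrolidine of compound 2. They also leave open what a longer chain on the nitrogen, or a carboxylic acid in place of the amine, would do to the number in this assay.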